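Adding an isopropyl group to the side chain of compound 2

A few compounds are considered here, and "the series" means these few. Any claim that something is new, unique, unknown or untested is made for them only; others in the source may bear on it.

Of the compounds shown here, two sharing one core have been measured so far in a functional assay on HeLa cells (Homo sapiens) for antiproliferative activity, read by MTT assay, with a stated time of 48 h (on this read-out lower numbers stand for stronger inhibition and higher numbers for weaker inhibition), and they set the scene. Compound 1 `COc1cc(/C=C/C(=O)N2Cc3ccccc3[C@@H](OCc3ccccc3)[C@@H]2CO)ccc1O` gives 67600 nM while compound 2 `Cc1ccc(S(=O)(=O)NCC(=O)N2Cc3ccccc3[C@@H](OCc3ccccc3)[C@@H]2CO)cc1` gives 15100 nM and so holds the lower of the two numbers, with a gap beyond the usual scatter of repeat measurements. Their side chains differ in more than one place, so this pair cannot show what any single group contributes.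

The next compound makes a much smaller change. Compound 3 `Cc1ccc(S(=O)(=O)N[C@H](C(=O)N2Cc3ccccc3[C@@H](OCc3ccccc3)[C@@H]2CO)C(C)C)cc1` differs from compound 2 in one place (isopropyl in place of hydrogen on a saturated chain carbon bound to a carbonyl carbon and a sulfonamide nitrogen): isopropyl in place of hydrogen on a saturated chain carbon bound to a carbonyl carbon and a sulfonamide nitrogen. Within the data shown here, no measured pair isolates this kind of change, so the expectation is loose. Only a small shift toward a lower number is expected in this assay and it should stay within the scatter. The estimated move is a 1.3-fold lower number from compound 2 to compound 3 (0.10 log units; within the scatter) and either direction remains possible. The estimated value for compound 3 is 12000 nM (expected range 4000 nM to 35000 nM).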

Compound 3, half-maximal inhibitory concentration: 92600 nM
Compound 3: the middle estimate sits 7.7-fold (0.89 log units) below what was measured; measured number above the stated range.
By their numbers in this assay, from the lowest: compound 2; then compounds 1 and 3 (each within the scatter of the next).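

In this assay, placing an isopropyl group on the saturated chain carbon bound to a carbonyl carbon and a sulfonamide nitrogen gives a 6.1-fold higher number from compound 2 to compound 3 (0.79 log units; beyond the scatter) and so shows that this carbon does not freely accept added groups. This is the first step shown that changes one place alone, which makes the isopropyl group the only structural difference within this pair. That single group, which brings no ring, no hydrogen-bond donors or acceptors and no net charge, is enough to move the result beyond the usual scatter toward weaker inhibition. Nothing measured here bears on the reason for this shift.

A single substituent cannot show whether the result depends on the particular group or on any replacement of hydrogen at this carbon, and a methyl group or a benzyl group at the same place would help to separate those possibilities. Also open is how the mirror-image arrangement of the isopropyl group at this carbon would read out, since only one arrangement appears among the compounds shown.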